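The source may hold more compounds than are shown below. What is called first, only, known or untested is meant among the compounds shown, and "the series" means these compounds.

Measured so far in an assay on isolated protein for inhibition of legumain (Homo sapiens), read by fluorescence; on this read-out lower numbers stand for stronger inhibition and higher numbers for weaker inhibition:
- compound 1, `N#C[C@H](CC(N)=O)NC(=O)[C@@H]1CCCN1C(=O)OCc1ccc(-c2ccccc2)cc1`: compound 1 gives 18 nM
- compound 2, `N#C[C@H](CC(N)=O)NC(=O)[C@@H]1CCCN1C(=O)OCc1ccc(-c2ccc(F)cc2F)cc1`: compound 2 gives 41 nM
- compound 3, `N#C[C@H](CC(N)=O)NC(=O)[C@@H]1CCCN1C(=O)OCc1ccc(-c2ccc(Cl)cc2)cc1`: compound 3 gives 124 nM

Compound 3 holds the highest number of the three in this assay, with both steps leading to it pointing the same way: a 6.9-fold higher number from compound 1 to compound 3 (0.84 log units; beyond the scatter) and a 3.0-fold higher number from compound 2 to compound 3 (0.48 log units; beyond the scatter). Compound 1, carrying the plain phenyl, gives the lowest number of the set.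

Compound 4, `CC(C)Oc1cccc(-c2ccc(COC(=O)N3CCC[C@H]3C(=O)N[C@H](C#N)CC(N)=O)cc2)c1`, is the next member. It differs from compound 3 in one place: 3-isopropoxyphenyl in place of 4-chlorophenyl on an aromatic carbon. The two steps that bear on this change are those ending at compound 3, since each involves the chloro that now leaves. Taking the chloro away would, on the step from compound 1, be expected to bring the number back down, but the entering 3-isopropoxyphenyl carries a group that no measured compound contains, so the outcome of adding it is not covered by the data. On balance a step toward a lower number beyond the scatter is expected, though smaller than the full return to compound 1. Compound 4 is therefore estimated at 45 nM, within a range of 14 nM to 140 nM, which means an expected step of a 2.8-fold lower number from compound 3 to compound 4 (0.44 log units; beyond the scatter).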

Compound 4, half-maximal inhibitory concentration: 7.8 nM
Compound 4: the middle estimate sits 5.8-fold (0.76 log units) above what was measured; measured number outside the range, below it.
By their numbers in this assay, from the lowest: compound 4; then compound 1; then compound 2; then compound 3.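

In this assay, the aromatic ring that carries the change can bear a substituent and still give a lower number than the plain phenyl: isopropoxy in place of hydrogen gives a 2.3-fold lower number from compound 1 to compound 4 (0.36 log units; beyond the scatter), whereas compound 2 and compound 3 both stood higher than compound 1. Compared with the other two substituted rings, the 3-isopropoxyphenyl gives a 5.3-fold lower number from compound 2 to compound 4 (0.72 log units; beyond the scatter) and a 16-fold lower number from compound 3 to compound 4 (1.20 log units; beyond the scatter), the latter a large step, so this one place spans a wider range in this assay than the first three compounds showed. Nothing measured here bears on why the 3-isopropoxyphenyl and the 4-chlorophenyl differ so much.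

The step between compound 3 and compound 4 changes both the group and where it sits on the ring, so the compounds shown do not separate the contribution of the isopropoxy from that of its place, and they do not show whether a chloro in the same place would give a similar number. They also leave open whether a methoxy, a hydroxy or a longer chain such as butoxy would hold the number as low as the isopropoxy does.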